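Hydroxyalkenyl in place of the chain enone: compound 3

The source may hold more compounds than are shown below. What is called first, only, known or untested is meant among the compounds shown, and "the series" means these compounds.

Measured in a functional assay on A549 cells (Homo sapiens) for cytotoxicity, read by MTT assay, with a stated time of 48 h; a lower number here means a stronger inhibitor, a higher number a weaker inhibitor:
Compound 1 `C=C[C@@](C)(/C=C/c1ccc(O)cc1)CCC(=O)C(=C)C` — given only as a limit, > 10000 nM
Compound 2 `CC(C)(O)[C@@H]1Oc2ccc(-c3coc4cc(O)ccc4c3=O)cc2[C@H]1O` — given only as a limit, > 10000 nM

Compound 1 stands at the limit of > 10000 nM in this assay, at which 2 of the 2 values shown sit, so no number is known for it, only that its half-maximal inhibitory concentration lies past the tested range. Compound 2 sits at the same limit, and nothing can be said of any order between the two.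

The unmeasured compound 3 `C=C[C@@](C)(/C=C/c1ccc(O)cc1)C/C=C/C(C)(C)O` differs from compound 1 by 3-hydroxy-3-methylbut-1-en-1-yl in place of ((1-methylethenyl)carbonyl)methyl on a saturated chain carbon, two bonds along the chain from two double-bonded chain carbons. The shared core of compound 1 is kept; the change is confined to the end of the chain.

Within the data shown here, because compound 1 sits at the limit of > 10000 nM in this assay, at which 2 of the 2 values shown sit, no measured step is available to size this change against, and no direction can be read from the data. The estimate therefore implies a step that the limit leaves unreadable from compound 1 to compound 3, expected to stay within the scatter. Compound 3 is expected to give 30000 nM, between 8000 nM and 100000 nM, most likely again returned only as a limit.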

Compound 3, half-maximal inhibitory concentration: > 10000 nM
Compound 3: a limit, no number; the forecaster's own chance of this, stated with the estimate: 80%; the middle value lies beyond the limit too.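

No step from compound 1 to compound 3 can be read, since both are given only as limits: the limit of > 10000 nM in this assay, at which 3 of the 3 values shown sit.

The compounds shown leave open whether any change at the end of the chain on the shared core yields a half-maximal inhibitory concentration readable as a number.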